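The compounds below may be only part of what the source reports. "The series", "measured", "known", "first", "only" and "open" are said of these compounds alone.

Working notes on the series, step from compound 2 to compound 4.

Compound 1 `N#Cc1ccc(-c2cnc3[nH]cc(-c4nnc(-c5ccc(Cl)cc5)o4)c(=O)c3c2)cc1` gives 7.6% in a functional assay on A549 cells (Homo sapiens) for inhibition, read by MTT assay, with a stated time of 24 h, tested at 5 uM; on this read-out higher numbers stand for more inhibition of growth at the one concentration tested and lower numbers for less inhibition of growth. Within the data shown here, compound 3 `O=c1c(-c2nnc(-c3ccc(Cl)cc3)o2)c[nH]c2ncc(-c3ccccc3)cc12` gives 1.44% in the same read-out, and the one step between measured compounds that differ in a single place, a number 6.2 percentage points lower from compound 1 to compound 3 (within the scatter), concerns the cyano group alone. Compound 2 `Cc1ccc(-c2nnc(-c3c[nH]c4ncc(-c5ccc(S(C)(=O)=O)cc5)cc4c3=O)o2)cc1` gives 6.69%; its number differs from that of compound 1 by less than the scatter and from that of compound 3 also by less than the scatter, so the three measured compounds cannot be told apart on these data.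

Compound 4 `Cc1cccc(-c2nnc(-c3c[nH]c4ncc(-c5ccc(S(C)(=O)=O)cc5)cc4c3=O)o2)c1` is not yet measured. It differs from compound 2 by 3-methylphenyl in place of 4-methylphenyl on an aromatic carbon. Among the measured compounds shown here, no measured step concerns the position of the methyl on this ring; the only step known, from compound 1 to compound 3, is small and on another part of the molecule. Because compound 2 gives 6.69% and that number sits among numbers that all lie within the scatter of one another, the step of a number 0.3 percentage points higher from compound 2 to compound 4 (within the scatter) is expected to stay within the scatter. Compound 4 is therefore estimated at 7%, with a range from -3% to 17%.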

Compound 4, percent growth inhibition at one concentration: 7.92%
Beside the measured number, compound 4's estimate is 0.9 percentage points below it; low and high end bracket the measured number.
By their numbers in this assay, from the lowest: compounds 3, 2, 1 and 4 (each within the scatter of the next).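

In this assay the exchange at the aromatic carbon of the five-membered aromatic ring gives a number 1.2 percentage points higher from compound 2 to compound 4 (within the scatter) as the only step shown at this place, one that the earlier comparison, confined to the cyano group on another part of the molecule, could not supply. With the same atoms on both sides, 3-methylphenyl and 4-methylphenyl cannot be told apart here, so moving the methyl on this ring gives no readable difference at the one concentration tested. No available evidence bears on this result.

From the compounds shown here alone, it remains open whether an amine, a carboxylic acid or a longer chain on this ring would give a step beyond the scatter. The compounds shown hold no step at this place that lies beyond the scatter, so the importance of this place for inhibition of growth remains unknown.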